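The source may hold more compounds than are shown below. What is called first, only, known or untested is meant among the compounds shown, and "the series" means these compounds.

The dihydrobenzofuran amides here were compared in an assay for inhibition of acyl-CoA:cholesterol acyltransferase (Oryctolagus cuniculus), using microsomes; on this read-out lower numbers stand for stronger inhibition and higher numbers for weaker inhibition. Compound 1 `CCCCCCCCCCC(C)(C)C(=O)Nc1c(C)c([N+](=O)[O-])c(C)c2c1OC(C)(C)C2` gives 36 nM in this assay, compound 2 `CCCCCCCCCCC1(C(=O)Nc2c(C)cc(C)c3c2OC(C)(C)C3)CCCC1` gives 170 nM, and compound 3 `CCCCCCCCC(C)(C)C(=O)Nc1c(C)cc(C)c2c1OC(C)(C)C2` gives 140 nM. On these three numbers compound 3 stands second highest: against compound 2 its value differs by an amount within the usual scatter, so no order between these two can be read, whereas compound 1 sits clearly lower, beyond the scatter.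

Compound 4 `Cc1cc(C)c(NC(=O)C(C)(C)CCCCCCN2CCCCC2)c2c1CC(C)(C)O2` differs from compound 3 in one place: piperidin-1-yl in place of ethyl on a saturated chain carbon, seven bonds along the chain from a carbonyl carbon. Going by the values given here, no pair of measured compounds shows a change of this kind, so its size has to be judged without a direct precedent. Since the shared core and the branched amide are kept and only the far end of the chain is altered, the step of a 1.4-fold higher number from compound 3 to compound 4 (0.15 log units; within the scatter) is expected to be modest and of uncertain direction, possibly not beyond the scatter. Compound 4 is therefore estimated at 200 nM, with a range from 50 nM to 800 nM.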

Compound 4, half-maximal inhibitory concentration: > 500 nM
Compound 4: a limit, no number (the forecaster's own chance of this, stated with the estimate: 5%); at least 2.5-fold (0.39 log units) between middle value and limit.
By their numbers in this assay, from the lowest: compound 1; then compounds 3 and 2 (each within the scatter of the next). At a limit, above all of these: compound 4.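

In this assay, piperidin-1-yl in place of ethyl on a saturated chain carbon, seven bonds along the chain from a carbonyl carbon, comes with an at least 3.5-fold higher number from compound 3 to compound 4 (0.55 log units; beyond the scatter). Going by these compounds alone, the earlier compounds carried only plain carbon chains at this end, so this is the first sign that the far end of the chain is not indifferent to what it holds. For compound 4 the read-out is a limit and not a number, so the step gives only a lower bound on the size of the change: the limit of > 500 nM in this assay, at which 1 of the 4 values shown sits.

Going by these compounds, whether the ring or its nitrogen goes with this step stays open: a cyclohexyl group at the same place would speak to the ring alone, and a dimethylamino group to the nitrogen alone. On these data alone, whether the same change would weigh as much on the core of compound 1, which carries a nitro group, also stays open.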